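The source may report more compounds than this note shows. Statements on the series, on what has been measured and on what is new or still open speak of the compounds shown alone.

The measured compounds:

Compound 1, `Cc1ccc(NC2=CC(=O)c3nc4n(c3C2=O)[C@H]2OC[C@@H](O)[C@H]2OC4)cc1C`, gives 2820 nM in a functional assay on ECa-109 cells for inhibition, with ECa-109 cell line (Homo sapiens) as the target, read by sulforhodamine B assay; a higher number here means a weaker inhibitor, a lower number a stronger inhibitor.
Compound 2, `CCCc1ccc(NC2=CC(=O)c3c(nc4n3[C@H]3OC[C@@H](O)[C@H]3OC4)C2=O)cc1`, gives > 4000 nM in this assay; this is a limit of the assay, not a number.
Compound 3, `O=C1C=C(N2CCCCC2)C(=O)c2c1nc1n2[C@H]2OC[C@@H](O)[C@H]2OC1`, gives > 8000 nM in this assay; this too is a limit, not a number.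

Only compound 1 has an exact value, and it is a weak one. Compound 2 stands at a limit, so all that is known is that it inhibits even less strongly than that boundary allows to say; two of the three values sit at such limits (the limit of > 4000 nM in this assay, at which 1 of the 3 values shown sits, (the limit of > 8000 nM in this assay, at which 1 of the 3 values shown sits)).

The unmeasured compound 4, `O=C1C(Nc2ccc(C(F)(F)F)cc2)=CC(=O)c2c1nc1n2[C@H]2OC[C@@H](O)[C@H]2OC1`, differs from compound 2 in one place: trifluoromethyl in place of propyl on an aromatic carbon. Within the data shown here, the only measured step, an at least 2.8-fold higher number from compound 1 to compound 3 (0.45 log units; beyond the scatter), exchanges the whole aromatic amine for a piperidine and does not concern a substituent swap on the aromatic ring, so it does not bear on this change. With compound 2 known only as a limit, the size and direction of the step cannot be read from the data. Compound 4 is expected to remain a weak inhibitor, with a step that the limit leaves unreadable from compound 2 to compound 4 estimated to stay near the boundary. Compound 4 is estimated at 5000 nM, within 1500 nM to 20000 nM.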

Compound 4, half-maximal inhibitory concentration: 2250 nM
Compound 4: middle estimate off by 2.2-fold (0.35 log units), on the high side; low and high end bracket the measured number.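

Trifluoromethyl in place of propyl, on an aromatic carbon para to a large group, gives an at least 1.7-fold lower number from compound 2 to compound 4 (0.24 log units; that floor lies within the scatter) in this assay. Compound 2 stands at a limit of the assay, not at a number: the limit of > 4000 nM in this assay, at which 1 of the 4 values shown sits. The true step may therefore be larger than this floor, but the floor alone does not separate the pair. What is new is that a substituent at this place can give an exact reading, with compound 4 at 2250 nM.

The compounds shown leave open whether a real difference separates propyl from trifluoromethyl at this place. They also leave open how a nitrile or a carboxylic acid would read on the same aromatic carbon.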